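Aromatic group restored on the hydrazone-limit compound

The source may hold more compounds than are shown below. What is called first, only, known or untested is meant among the compounds shown, and "the series" means these compounds.

Compound 3 `CSCC/C=N/Nc1nc(N)c2ncn([C@@H]3O[C@H](CO)[C@@H](O)[C@H]3O)c2n1` carries 2-(methylsulfanyl)ethyl on a carbon with a double bond to nitrogen. In an assay on CHO-K1 cells for displacement of a labelled ligand from adenosine receptor A1 (Homo sapiens), read by scintillation counting, with a stated time of 60 min (a higher number here means a weaker inhibitor, a lower number a stronger inhibitor), compound 3 gives only a limit, > 10000 nM, and so sits at the limit of > 10000 nM in this assay, at which 1 of the 3 values shown sits. Compound 1 `Nc1nc(N/N=C/c2cncs2)nc2c1ncn2[C@@H]1O[C@H](CO)[C@@H](O)[C@H]1O`, with 1,3-thiazol-5-yl in that place, gives 22 nM in this assay. Compound 2 `Nc1nc(N/N=C/c2cccnc2Cl)nc2c1ncn2[C@@H]1O[C@H](CO)[C@@H](O)[C@H]1O`, with 2-chloropyridin-3-yl in that place, gives 4.6 nM in this assay. The change to compound 4 `COc1ccc(/C=N/Nc2nc(N)c3ncn([C@@H]4O[C@H](CO)[C@@H](O)[C@H]4O)c3n2)cn1` is 6-methoxypyridin-3-yl in place of 2-(methylsulfanyl)ethyl on a carbon with a double bond to nitrogen. The measured steps that bear on it run in the opposite direction: an at least 450-fold higher number from compound 1 to compound 3 (2.65 log units; beyond the scatter) and an at least 2100-fold higher number from compound 2 to compound 3 (3.33 log units; beyond the scatter), both large losses when the chain took the place of a ring, whereas between the two rings the step was only a 4.8-fold lower number from compound 1 to compound 2 (0.68 log units; beyond the scatter). Since a six-membered aromatic ring with 1 hetero atom enters again, a large step down in this assay is expected for compound 4, an at least 660-fold lower number from compound 3 to compound 4 (2.82 log units; beyond the scatter), though its exact size is uncertain because compound 3 rests on a limit. Compound 4 is estimated at 15 nM, within a range of 3 nM to 80 nM.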

Compound 4, inhibition constant: 2.6 nM
For compound 4 the middle estimate is 5.8-fold (0.76 log units) above the measured one; measured number below the stated range.
By their numbers in this assay, from the lowest: compounds 4 and 2 (each within the scatter of the next); then compound 1. At a limit, above all of these: compound 3.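

In this assay compound 3 stands only as a limit: the limit of > 10000 nM in this assay, at which 1 of the 4 values shown sits.

Even so, an at least 3800-fold lower number from compound 3 to compound 4 (3.58 log units; beyond the scatter) shows that a third aromatic ring, 6-methoxypyridin-3-yl, also recovers what is lost with 2-(methylsulfanyl)ethyl on a carbon with a double bond to nitrogen. Within this set, the step of a 1.8-fold lower number from compound 2 to compound 4 (0.25 log units; within the scatter) leaves 6-methoxypyridin-3-yl and 2-chloropyridin-3-yl undistinguished, whereas an 8.5-fold lower number from compound 1 to compound 4 (0.93 log units; beyond the scatter) sets 6-methoxypyridin-3-yl apart from 1,3-thiazol-5-yl.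

As far as these compounds go, what the methoxy group itself contributes stays open: a plain pyridin-3-yl, or an amine in its place, would separate the ring from its substituent. With 2-(methylsulfanyl)ethyl as the only open chain shown, it also remains open whether a longer chain or one ending in a carboxylic acid would fare any better.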